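Swapping a hydroxy group for ethyl on the triazole side chain

The compounds below may be only part of what the source reports. "The series", "measured", "known", "first", "only" and "open" are said of these compounds alone.

Compound 1 `O=C1O[C@H]([C@@H](O)Cn2cc(CCO)nn2)C(OCc2ccccc2)=C1OCc1ccccc1` and compound 2 `O=C1O[C@H]([C@@H](O)Cn2cc(-c3cc(C(F)(F)F)cc(C(F)(F)F)c3)nn2)C(OCc2ccccc2)=C1OCc1ccccc1` share a core and differ only in the group carried by the triazole ring. Within the data shown here, in a functional assay on HeLa cells (Homo sapiens) for antiproliferative activity, read by MTT assay, with a stated time of 72 h (a higher number here means a weaker inhibitor, a lower number a stronger inhibitor), compound 1 gives 68800 nM, the highest of the two numbers known so far, while compound 2 gives 35500 nM, a value within the scatter of that of compound 1. Compound 3 `CCCCc1cn(C[C@H](O)[C@H]2OC(=O)C(OCc3ccccc3)=C2OCc2ccccc2)nn1` differs from compound 1 in one place: ethyl in place of hydroxy on a saturated chain carbon, two bonds along the chain from an aromatic carbon. Among the measured compounds shown here, no step between two measured compounds informs this change, so for compound 3 a step of a 1.6-fold lower number from compound 1 to compound 3 (0.21 log units; within the scatter) is expected, at most a small move toward a lower number and not beyond the scatter. Compound 3 is therefore estimated at 42000 nM, within a range from 15000 nM to 110000 nM.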

Compound 3, half-maximal inhibitory concentration: 18100 nM
Compound 3: the middle estimate sits 2.3-fold (0.37 log units) above what was measured; the measured number falls inside the stated range.
By their numbers in this assay, from the lowest: compounds 3, 2 and 1 (each within the scatter of the next, the first and the last beyond it).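

Replacing hydroxy with ethyl gives a 3.8-fold lower number from compound 1 to compound 3 (0.58 log units; beyond the scatter) in this assay, so the end of this chain on the triazole does influence the read-out. The step is modest, but it shows that the hydroxy group is not required for antiproliferative activity in these cells. No measurement shown here explains the step.

Among these compounds, the single change removes hydroxy and adds ethyl together, so the contribution of each remains unknown. Also open, going by these compounds, is how an amine, a carboxylic acid or a chain longer than butyl would behave at this position.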